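Cyclohexyl gives way to 4-methoxyphenyl

The source may hold more compounds than are shown below. What is called first, only, known or untested is meant among the compounds shown, and "the series" means these compounds.

Measured in an ADME assay on cells (Hepatocyte, Mus musculus) for metabolic stability, with a stated time of 30 min; on this read-out higher numbers stand for a more stable compound and lower numbers for a less stable compound:
- Compound 1 `O=C(OC1CCC(CN2CCN(c3cc(=O)c4cc(C(F)(F)F)cc([N+](=O)[O-])c4s3)CC2)CC1)c1ccco1`: 0.6%
- Compound 2 `O=C(OC1CCC(CN2CCN(c3cc(=O)c4cc(C(F)(F)F)cc([N+](=O)[O-])c4s3)CC2)CC1)c1ccc(C(F)(F)F)cc1`: 28.8%
- Compound 3 `O=C(OC1CCC(CN2CCN(c3cc(=O)c4cc(C(F)(F)F)cc([N+](=O)[O-])c4s3)CC2)CC1)C1CCCCC1`: 1.2%

Compound 3 gives 1.2%, which cannot be told apart from the value of compound 1: the measured step is a number 0.6 percentage points higher from compound 1 to compound 3 (within the scatter). Compound 2 stands well clear of both, with a number 27.6 percentage points lower from compound 2 to compound 3 (beyond the scatter).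

The next compound, compound 4 `COc1ccc(C(=O)OC2CCC(CN3CCN(c4cc(=O)c5cc(C(F)(F)F)cc([N+](=O)[O-])c5s4)CC3)CC2)cc1`, has 4-methoxyphenyl in place of cyclohexyl on a carbonyl carbon.

Going by the values given here, two measured steps bear most directly on this change. Compound 2 also carries a substituted phenyl group on the carbonyl carbon, and its step from the furan-2-yl compound is a number 28.2 percentage points higher from compound 1 to compound 2 (beyond the scatter). The step from compound 2 to the cyclohexyl compound, already given above, is of similar size in the opposite direction. Still, compound 1 carries an aromatic furan-2-yl group and gives only 0.6%, so an aromatic ring alone does not ensure a high number. Among the compounds with values here, no measured compound carries a methoxy group either. A rise is therefore expected, but a smaller one than compound 2 showed.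

The estimated step is a number 10.8 percentage points higher from compound 3 to compound 4 (beyond the scatter).

For compound 4 the expected value is 12%, with an estimated range from 2% to 32%.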

Compound 4, percent of the compound remaining: 31%
Estimate against measurement, compound 4: 19 percentage points below; measured number inside the range.
By their numbers in this assay, from the lowest: compounds 1 and 3 (each within the scatter of the next); then compounds 2 and 4 (each within the scatter of the next).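

In this assay a second substituted phenyl group on this carbonyl carbon also gives a high number, with a number 29.8 percentage points higher from compound 3 to compound 4 (beyond the scatter) and a number 30.4 percentage points higher from compound 1 to compound 4 (beyond the scatter), so the result for compound 2 no longer stands alone. Methoxy in place of trifluoromethyl on the aromatic carbon makes no difference that can be told apart, with a number 2.2 percentage points higher from compound 2 to compound 4 (within the scatter), so among these four compounds the two substituted phenyl groups go with the high numbers, while cyclohexyl and furan-2-yl go with the low numbers, and the aromatic furan-2-yl of compound 1 shows that being aromatic is not enough for a high number. No measurement shown explains why these groups differ in this way.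

The compounds shown leave open whether a plain phenyl group on this carbonyl carbon would match the two substituted ones, or whether the high numbers depend on having a group at the 4 place of the phenyl. They also leave open whether the same holds for a very different group there, such as an amine or a carboxylic acid in 4-aminophenyl or 4-carboxyphenyl.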